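Paw edema inhibition after removing the methoxy of compound 2

The source may hold more compounds than are shown below. What is called first, only, known or untested is meant among the compounds shown, and "the series" means these compounds.

Measured so far in a functional assay on the whole organism (strain Wistar Albino) for inhibition, with Rattus norvegicus as the target, read by paw edema, with a stated time of 1 h, at a dose of 20 mg/kg; a lower number here means less inhibition, a higher number more inhibition at the dose given (going by the name of the read-out):
Compound 1 `Cc1occc1-c1nnc2sc(-c3ccnc(Cl)c3)nn12` gives 10.1%.
Compound 2 `COc1ccc2[nH]cc(Cc3nn4c(-c5ccoc5C)nnc4s3)c2c1` gives 16%.
Compound 3 `COc1ccc2[nH]c(C)c(Cc3nn4c(-c5ccoc5C)nnc4s3)c2c1` gives 19.7%.

Compound 2 stands second highest of the three numbers. Its nearest is compound 3, the step of a number 3.7 percentage points higher from compound 2 to compound 3 (within the scatter) lying within the scatter; compound 1 is furthest, and the two values of compound 1 and compound 2 also fall within the scatter of each other.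

Compound 4 `Cc1occc1-c1nnc2sc(Cc3c[nH]c4ccccc34)nn12` differs from compound 2 by hydrogen in place of methoxy on an aromatic carbon. Going by the values given here, the single measured step, a number 3.7 percentage points higher from compound 2 to compound 3 (within the scatter), concerns methyl in place of hydrogen on an aromatic carbon, not hydrogen in place of methoxy; no measured step bears directly on this change. Compound 4 is therefore expected to sit close to compound 2, with a step of a number 2 percentage points lower from compound 2 to compound 4 (within the scatter) that stays within the scatter. The estimate for compound 4 is 14%, ranging from 6% to 24%.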

Compound 4, a percentage reported as inhibition, in the whole organism at one dose (the size of the read-out at that dose, not a potency): 16%
For compound 4 the middle estimate is 2 percentage points below the measured one; measured number inside the range.
By their numbers in this assay, from the lowest: compounds 1, 2, 4 and 3 (each within the scatter of the next).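

In this assay the replacement of methoxy by hydrogen gives no change at the digits printed from compound 2 to compound 4 (within the scatter) and is the first step shown at this place on the six-membered aromatic ring. The earlier compounds shown here showed only a methyl step elsewhere, whereas this result shows that, at this dose, the reading of compound 2 is kept without the methoxy. Nothing available accounts for this outcome.

As far as these compounds go, whether a hydroxyl, a fluorine or an amine at this place would shift the reading remains open. Also open, from the compounds shown here alone, is whether the same replacement would behave alike with the added methyl of compound 3 present.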